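Phenyl for Dimethylamino at a Second Place

The compounds below may be only part of what the source reports. "The series", "measured", "known", "first", "only" and "open" are said of these compounds alone.

In an assay on isolated protein for displacement of a labelled ligand from 5-hydroxytryptamine receptor 6 (Homo sapiens), read by scintillation counting, with a stated time of 1 h (on this read-out lower numbers stand for stronger inhibition and higher numbers for weaker inhibition), compound 1 `CN(C)c1cn(S(=O)(=O)c2ccccc2)c2ccccc12` gives 474 nM and compound 2 `O=S(=O)(c1ccccc1)n1cc(-c2ccccc2)c2ccccc21` gives 146 nM. The change between them is phenyl in place of dimethylamino on an aromatic carbon, and it made the step of a 3.2-fold lower number from compound 1 to compound 2 (0.51 log units; beyond the scatter). Compound 3 `CN(C)c1ccc2ccn(S(=O)(=O)c3ccccc3)c2c1` has the same atoms as compound 1, joined differently; the difference between the two cores is not broken down here. In this assay compound 3 gives 211 nM. Compound 4 `O=S(=O)(c1ccccc1)n1ccc2ccc(-c3ccccc3)cc21` is not yet measured; it differs from compound 3 by phenyl in place of dimethylamino on an aromatic carbon. This is the same kind of change as before, but at a different place: in compound 1 the group sat on a five-membered aromatic ring with 1 nitrogen, here on a six-membered aromatic ring of carbon only, meta and para to a fused ring. Because the earlier step of a 3.2-fold lower number from compound 1 to compound 2 (0.51 log units; beyond the scatter) lay beyond the scatter, a somewhat smaller step of a 2.1-fold lower number from compound 3 to compound 4 (0.32 log units; beyond the scatter) is expected here, since the place differs. Compound 4 is therefore estimated at 100 nM.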

Compound 4, inhibition constant: 178 nM
Estimate against measurement, compound 4: 1.8-fold (0.25 log units) below; measured number inside the range.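

At the second place, phenyl in place of dimethylamino makes a 1.2-fold lower number from compound 3 to compound 4 (0.07 log units; within the scatter) in this assay. Going by these compounds alone, with only two pairs in hand, this does not show whether the place, the core or both set the size of the step, and it gives no rule for any further core. What it does show is that the size of the step did not carry over from one core to the other: the same change on two cores in this assay, a 3.2-fold lower number (0.51 log units; beyond the scatter) from compound 1 to compound 2 and a 1.2-fold lower number (0.07 log units; within the scatter) from compound 3 to compound 4, 2.7-fold (0.44 log units) apart, beyond the scatter of two such steps

The compounds shown leave open how other groups at these two places, such as a carboxylic acid or a methoxy group, would compare with phenyl and dimethylamino. They also leave open whether the phenyl step would stay large or small at the remaining places on either core.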